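Swapping Methyl for Chloro on a Weak Inhibitor

The compounds below may be only part of what the source reports. "The series", "measured", "known", "first", "only" and "open" are said of these compounds alone.

Compound 1 `COc1cc2ncnc(-n3nc(-c4ccccn4)cc3N)c2cc1OC` gives 1600 nM in an assay on MCF7 cells for inhibition of Serine-protein kinase ATM (Homo sapiens), read by immunofluorescence, with a stated time of 1 h; a lower number here means a stronger inhibitor, a higher number a weaker inhibitor. Compound 2 `COc1cc2ncnc(-n3nc(-c4ccc(C)cc4)cc3N)c2cc1OC` reaches the limit of this assay, > 40000 nM. The step of an at least 25-fold higher number from compound 1 to compound 2 (1.39 log units; beyond the scatter) is the only measured one, and it ends at the limit (the limit of > 40000 nM in this assay, at which 1 of the 2 values shown sits), so compound 2 stands at the weak end of what the assay can read. Compound 3 `COc1cc2ncnc(-n3nc(-c4ccc(Cl)cc4)cc3N)c2cc1OC` differs from compound 2 by chloro in place of methyl on an aromatic carbon. Going by the values given here, no measured step covers this change, so no movement beyond the scatter is predicted in either direction. Compound 3 is expected to stay near the limit, an expected step of a number no higher from compound 2 to compound 3 (the limit leaves the size open). The estimate for compound 3 is 40000 nM, expected between 8000 nM and 200000 nM.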

Compound 3, half-maximal inhibitory concentration: > 40000 nM
Compound 3 was reported as a limit; the forecaster's own chance of this, stated with the estimate: 70%; the middle value sits exactly at the limit.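

With chloro at this place on the ring, para to a large group, the weak result recurs: 4-chlorophenyl in place of pyridin-2-yl gives an at least 25-fold higher number from compound 1 to compound 3 (1.39 log units; beyond the scatter). The loss seen with 4-methylphenyl is therefore not confined to the methyl group. The step between compound 2 and compound 3 cannot be read, and methyl and chloro cannot be ranked here: the limit of > 40000 nM in this assay, at which 2 of the 3 values shown sit.

Still open, from the compounds shown here alone, is whether plain phenyl, with no group at this place, is just as weak. An amine or a carboxylic acid here might also bring the value back within the range the assay can read.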